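The source may hold more compounds than are shown below. What is called first, only, known or untested is meant among the compounds shown, and "the series" means these compounds.

Working notes on the sulfonate series.

In a functional assay on MCF7 cells (Homo sapiens) for antiproliferative activity, read by sulforhodamine B assay, with a stated time of 48 h (a higher number here means a weaker inhibitor, a lower number a stronger inhibitor), compound 1 `CCCNC(=O)Nc1ccc(S(=O)(=O)Oc2ccccc2C(C)C)cc1` gives 2700 nM and compound 2 `CCCNC(=O)Nc1ccc(S(=O)(=O)Oc2ccccc2I)cc1` gives 2900 nM. Compound 2 differs from compound 1 by iodo in place of isopropyl on an aromatic carbon, and that step reads a 1.1-fold higher number from compound 1 to compound 2 (0.03 log units; within the scatter). Compound 3 `CC(C)c1ccccc1OS(=O)(=O)c1ccc(NC(=O)NCCCCl)cc1` gives 7400 nM in this assay and is the weakest of the three measured; the difference between its core and the core of compound 1 is chloro in place of hydrogen on a saturated chain carbon, three bonds along the chain from an amide-type nitrogen, with the step of a 2.7-fold higher number from compound 1 to compound 3 (0.44 log units; beyond the scatter).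

Compound 4 `O=C(NCCCCl)Nc1ccc(S(=O)(=O)Oc2ccccc2I)cc1` has not yet been measured in this assay. It differs from compound 3 by iodo in place of isopropyl on an aromatic carbon, the same change that separates compound 1 from compound 2: the place lines of the two changes agree word for word, so this is the same change made on the core of compound 3. Going by the values given here, with only one earlier instance to go on, the step from compound 3 to compound 4 is expected to be about a 1.1-fold higher number from compound 3 to compound 4 (0.03 log units; within the scatter), resting on compound 1 and compound 2, where the same change gave a 1.1-fold higher number from compound 1 to compound 2 (0.03 log units; within the scatter). Compound 4 is therefore expected to come out near 8000 nM in this assay, estimated between 4000 nM and 16000 nM.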

Compound 4, half-maximal inhibitory concentration: 7600 nM
Beside the measured number, compound 4's estimate is 1.1-fold (0.02 log units) above it, and the stated range covers the measured number.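

In this assay, iodo in place of isopropyl on an aromatic carbon again leaves the number essentially where it was, with a 1.0-fold higher number from compound 3 to compound 4 (0.01 log units; within the scatter), and this null result carries from one core to the other: the same change on two cores in this assay, a 1.1-fold higher number (0.03 log units; within the scatter) from compound 1 to compound 2 and a 1.0-fold higher number (0.01 log units; within the scatter) from compound 3 to compound 4, 1.0-fold (0.02 log units) apart, within the scatter of two such steps

Chloro in place of hydrogen on the saturated chain carbon also carries over with the iodo group in place, with a 2.6-fold higher number from compound 2 to compound 4 (0.42 log units; beyond the scatter), a modest weakening that matches the earlier one: the same change on two cores in this assay, a 2.7-fold higher number (0.44 log units; beyond the scatter) from compound 1 to compound 3 and a 2.6-fold higher number (0.42 log units; beyond the scatter) from compound 2 to compound 4, 1.0-fold (0.02 log units) apart, within the scatter of two such steps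

Across these four compounds the two changes therefore read as independent of each other, but each rests on only two cores in a single cell assay, so this shows neither a general rule for the series nor any reason for the agreement.

From the compounds shown here alone, it remains open whether the same independence holds for other groups at these places, such as bromo or methoxy on the aromatic carbon, or an amine or a longer chain at the chloro end. Going by these compounds, how either change reads on a core with a different link than the sulfonate also stays open.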